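This account rests on a few compounds, and the source may have more. Where it says the series, first, only, none or still open, it means among the compounds named here.

Compound 1 `CC1CC1C(=O)N1CCc2nc(C#Cc3ccccc3)sc2C1`: 9.4 nM
Compound 2 `CC1CCC(C(=O)N2CCc3nc(C#Cc4ccccc4)sc3C2)CC1`: 190 nM
Compound 3 `N#Cc1cccc(C(=O)N2CCc3nc(C#Cc4ccccc4)sc3C2)c1`: 71 nM

These three values come from an assay on HEK293 cells for positive allosteric modulation of metabotropic glutamate receptor 5 (Homo sapiens), read by FLIPR, with a stated time of 1 h; a lower number here means that less compound is needed, a higher number that more compound is needed for the effect. Among them compound 1 stands lowest, with compound 3 nearest at a 7.6-fold higher number from compound 1 to compound 3 (0.88 log units; beyond the scatter) and compound 2 furthest at a 20-fold higher number from compound 1 to compound 2 (1.31 log units; beyond the scatter). Compound 4 `CC(C)S(=O)(=O)N1CCc2nc(C#Cc3ccccc3)sc2C1` has not yet been measured. It differs from compound 1 in one place: isopropylsulfonyl in place of (2-methylcyclopropyl)carbonyl on an amine nitrogen in a ring. The two measured steps that start from compound 1 each swap the group on the carbonyl carbon, and both raise the number, one modestly and one by a large amount. Among the compounds with values here, the change to compound 4 goes further, since the carbonyl itself leaves and a sulfonyl enters, so no measured step matches it closely. A higher number is therefore expected for compound 4, most likely a modest to large rise, a 6.4-fold higher number from compound 1 to compound 4 (0.81 log units; beyond the scatter). Compound 4 is estimated at 60 nM, within the range 12 nM to 300 nM.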

Compound 4, half-maximal effective concentration: > 10000 nM
Compound 4: a limit, no number; the forecaster's own chance of this, stated with the estimate: 10%; middle value at least 160-fold (2.22 log units) away from the limit.
By their numbers in this assay, from the lowest: compound 1; then compound 3; then compound 2. At a limit, above all of these: compound 4.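

Compound 4 carries a limit, not a number: the limit of > 10000 nM in this assay, at which 1 of the 4 values shown sits.

Even so, the move to the sulfonyl gives an at least 1000-fold higher number from compound 1 to compound 4 (3.02 log units; beyond the scatter), a far larger step than either change of the group on the carbonyl carbon. The earlier compounds shown here showed that this amine nitrogen tolerates quite different carbonyl groups, and compound 4 shows that the carbonyl link itself cannot simply be exchanged for a sulfonyl here.

On these data alone, what stays open is whether the sulfonyl or the isopropyl matters more. An isopropylcarbonyl or a phenylsulfonyl group on the same nitrogen would separate the two.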